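This account rests on a few compounds, and the source may have more. Where it says the series, first, only, none or still open, it means among the compounds named here.

Compound 1 `Nc1ccccc1NC(=O)c1ccc(CSC(=S)N2CCN(c3ccc(Cl)cc3)CC2)cc1`: 51.2%
Compound 2 `Nc1ccccc1NC(=O)c1ccc(CSC(=S)N2CCN(c3ccccc3)CC2)cc1`: 62.2%
Compound 3 `Nc1ccccc1NC(=O)c1ccc(CSC(=S)N2CCN(Cc3ccncc3)CC2)cc1`: 59.5%

In a functional assay on HeLa cells (Homo sapiens) for antiproliferative activity, read by CCK-8 assay, with a stated time of 72 h, tested at 2 uM (a lower number here means a weaker effect, a higher number a stronger effect of the compound at the concentration tested), compound 3 gives 59.5%, the second highest of these three numbers; its nearest neighbour is compound 2 and its furthest is compound 1, both within the scatter. Compound 4 `Nc1ccccc1NC(=O)c1ccc(CSC(=S)N2CCN(c3ncccn3)CC2)cc1` differs from compound 3 in one place: pyrimidin-2-yl in place of (pyridin-4-yl)methyl on an amine nitrogen in a ring. Going by the values given here, two measured steps bear on this change, a number 2.7 percentage points lower from compound 2 to compound 3 (within the scatter) and a number 8.3 percentage points higher from compound 1 to compound 3 (within the scatter). Both exchange a group on the amine nitrogen in a ring for the (pyridin-4-yl)methyl group, and neither moves the number beyond the scatter, so no step beyond the scatter is expected in this assay here either. Compound 4 is estimated at 58%, expected to fall between 45% and 70%, which corresponds to an expected a number 1.5 percentage points lower from compound 3 to compound 4 (within the scatter).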

Compound 4, a percentage reported as inhibition, at one concentration (the size of the read-out at that concentration, not a potency): 52.2%
Beside the measured number, compound 4's estimate is 5.8 percentage points above it; low and high end bracket the measured number.
By their numbers in this assay, from the lowest: compounds 1, 4, 3 and 2 (each within the scatter of the next, the first and the last beyond it).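

In this assay, swapping in pyrimidin-2-yl gives a number 7.3 percentage points lower from compound 3 to compound 4 (within the scatter) and a number 10 percentage points lower from compound 2 to compound 4 (within the scatter) and a number 1 percentage points higher from compound 1 to compound 4 (within the scatter). So at this amine nitrogen in a ring, a six-membered aromatic ring with 2 hetero atoms produces no step beyond the scatter against any of the three earlier groups. Nothing available here explains these numbers. Going by these compounds, whether a saturated amine such as a piperidine, a carboxylic acid or a longer alkyl chain at this nitrogen would keep the read-out in the same range remains open.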